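A Primary Amine in Place of a Dimethylamino Group

This account rests on a few compounds, and the source may have more. Where it says the series, first, only, none or still open, it means among the compounds named here.

Measured compounds:
compound 1 `O=C1[C@H](CCc2ccccc2)N(Cc2ccc(-c3ccccc3-c3nn[nH]n3)cc2F)C(=O)N1CCCN1CCCCC1` with 1600 nM
compound 2 `CN(C)CCCN1C(=O)[C@H](CCc2ccccc2)N(Cc2ccc(-c3ccccc3-c3nn[nH]n3)cc2)C1=O` with 4000 nM
compound 3 `O=C1[C@H](Cc2c[nH]c3ccccc23)N(Cc2ccc(-c3ccccc3-c3nn[nH]n3)cc2)C(=O)N1C1CCNCC1` with 50000 nM

Of the compounds shown here, three sharing one core have been tested in an in vitro assay on BHK cells for binding affinity to growth hormone secretagogue receptor type 1 (Homo sapiens); a lower number here means a stronger inhibitor, a higher number a weaker inhibitor. Compound 1 gives 1600 nM, compound 2 gives 4000 nM, and compound 3 gives 50000 nM. Compound 2 therefore stands second highest of the three numbers: compound 1 lies nearest, with a number beyond the scatter lower, while compound 3 lies furthest, with a number well beyond the scatter higher.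

Compound 4 `NCCCN1C(=O)[C@H](CCc2ccccc2)N(Cc2ccc(-c3ccccc3-c3nn[nH]n3)cc2)C1=O` has not yet been measured. It differs from compound 2 in one place: amino in place of dimethylamino on a saturated chain carbon, three bonds along the chain from an amide-type nitrogen in a ring. Among the compounds with values here, no pair of measured compounds shows this exact change on its own, so its effect has to be guessed. In the absence of such a comparison, the expected step from compound 2 to compound 4 in this assay is no change at the digits printed from compound 2 to compound 4 (within the scatter), which is taken to stay within the scatter, in no firm direction. Compound 4 is accordingly estimated to give about 4000 nM in this assay, with a likely range from 1200 nM to 14000 nM.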

Compound 4, half-maximal inhibitory concentration: > 100000 nM
Compound 4 was reported as a limit; the forecaster's own chance of this, stated with the estimate: 5%; middle value at least 25-fold (1.39 log units) from the limit.
By their numbers in this assay, from the lowest: compound 1; then compound 2; then compound 3. At a limit, above all of these: compound 4.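

In this assay, the end of this chain proves far from indifferent: replacing dimethylamino with amino, which turns 3-(dimethylamino)propyl into 3-aminopropyl, gives an at least 25-fold higher number from compound 2 to compound 4 (1.39 log units; beyond the scatter). Within the data shown here, compound 4 gives > 100000 nM, which is a limit of the assay and not a number: the limit of > 100000 nM in this assay, at which 1 of the 4 values shown sits. The earlier compounds differ from one another in more than one place, so they could not isolate this position; this pair shows that a change confined to the chain end, removing only the methyl groups, is enough to produce a large step.

Still open, from the compounds shown here alone, is whether removing a single methyl group would matter as much, which a methylamino group at the same place would test. Also open, going by these compounds, is how an acetamide at the chain end, or a longer chain ending in an amino group, would read.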